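The source may hold more compounds than are shown below. What is called first, only, known or untested is meant among the compounds shown, and "the series" means these compounds.

Two compounds sharing one core have numbers in an in vitro ADME assay on microsomes from liver (Homo sapiens) for pharmacokinetics, read by LC-MS, with a stated time of 10 min, tested at 1 uM; a lower number here means slower removal, a higher number faster removal of the compound. Compound 1 `CN1C[C@H](C(=O)Nc2ccc(C#N)cc2)[C@@H](c2ccc(/C=C/C(=O)Nc3ccccc3N)cc2)C1` gives 1 mL/min/kg. Compound 2 `CC(C)c1ccc(NC(=O)[C@H]2CN(C)C[C@@H]2c2ccc(/C=C/C(=O)Nc3ccccc3N)cc2)cc1` gives 10 mL/min/kg, the higher of the two numbers. Among the measured compounds shown here, the only measured step is a 10-fold higher number from compound 1 to compound 2 (1.00 log units; beyond the scatter), with isopropyl in place of cyano on an aromatic carbon.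

Compound 3 `CN1C[C@H](C(=O)Nc2cccc(Cl)c2)[C@@H](c2ccc(/C=C/C(=O)Nc3ccccc3N)cc2)C1` has not yet been measured. It differs from compound 2 in one place, with 3-chlorophenyl in place of 4-isopropylphenyl on an amide-type nitrogen. For the measured compounds named here, the isopropyl group leaves here too, so the one measured step is the only guide, and compound 1 at 1 mL/min/kg shows how low a number can go without that group. Going by the values given here, it is a weak guide, since chlorine replaces isopropyl here rather than cyano, and no measured compound carries 3-chlorophenyl. A move towards a lower number is therefore expected, but a smaller one than the measured step. The expected step is a 2.5-fold lower number from compound 2 to compound 3 (0.40 log units; beyond the scatter). For compound 3 the estimated value is 4 mL/min/kg, with an expected range from 1 mL/min/kg to 12 mL/min/kg.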

Compound 3, clearance: 7 mL/min/kg
The estimate for compound 3 lay 1.8-fold (0.24 log units) below the measured number; measured number inside the range.
By their numbers in this assay, from the lowest: compound 1; then compounds 3 and 2 (each within the scatter of the next).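

In this assay, the change at the amide-type nitrogen from 4-isopropylphenyl to 3-chlorophenyl gives a 1.4-fold lower number from compound 2 to compound 3 (0.15 log units; within the scatter), so losing the isopropyl group does not in itself bring the number close to that of compound 1. Replacing 4-cyanophenyl with 3-chlorophenyl at the same nitrogen gives a 7.0-fold higher number from compound 1 to compound 3 (0.85 log units; beyond the scatter), and among these three compounds the low number therefore goes with 4-cyanophenyl alone, a pattern that rests on compound 1 as its single example. No supporting measurement is available to explain why the numbers fall this way.

The compounds leave open whether the nitrile itself or its place on the ring sets compound 1 apart, since compound 3 differs from it in both the group and where that group sits on the phenyl ring. They also leave open how this position would respond to a methoxy group, an amine or a carboxylic acid on that ring, and whether the same gap would appear on any core other than the shared one.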